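Aryl amine in place of benzyl amine: growth-inhibition outlook

This account rests on a few compounds, and the source may have more. Where it says the series, first, only, none or still open, it means among the compounds named here.

Of the compounds shown here, two have been measured in an ADME assay on L02 cells (Homo sapiens) for inhibition, read by CCK-8 assay, with a stated time of 48 h; on this read-out higher numbers stand for weaker inhibition of growth and lower numbers for stronger inhibition of growth. Compound 1 `CCN1CCN(c2ccc(Nc3ncc(Cl)c(Nc4ccccc4C)n3)cc2)CC1` gives 970 nM in this assay. Compound 2 `CN1CCN(c2ccc(Nc3ncc(Cl)c(NCc4ccc(F)cc4)n3)nc2)CC1` gives 39700 nM in this assay, the higher of the two numbers, and the gap to compound 1 lies well beyond the scatter; compound 2 therefore stands as the weaker growth inhibitor of the pair. Within the data shown here, no pair differing in a single place has been measured, so no single-step size is known directly.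

Compound 3 `Cc1cc(C)c(Nc2nc(Nc3ccc(N4CCN(C)CC4)cn3)ncc2Cl)c(C)c1` is unmeasured. It differs from compound 2 in one place: 2,4,6-trimethylphenyl in place of 4-fluorobenzyl on a nitrogen on an aromatic ring. With that change the amine on the shared core carries an aromatic ring directly, as it does in compound 1, rather than through a one-carbon link.

The expectation for compound 3 is a step toward stronger growth inhibition, a 6.6-fold lower number from compound 2 to compound 3 (0.82 log units; beyond the scatter), of moderate size, because compound 1 with a directly attached aromatic ring on that nitrogen gives 970 nM. Compound 3 is estimated at 6000 nM in this assay, with a range from 1500 nM to 25000 nM.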

Compound 3, concentration for 50% growth inhibition: 20500 nM
Beside the measured number, compound 3's estimate is 3.4-fold (0.53 log units) below it; the measured number falls inside the stated range.
By their numbers in this assay, from the lowest: compound 1; then compounds 3 and 2 (each within the scatter of the next).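

In this assay, among these compounds, the first step that changes a single place gives a 1.9-fold lower number from compound 2 to compound 3 (0.29 log units; within the scatter), with 2,4,6-trimethylphenyl in place of 4-fluorobenzyl on a nitrogen on an aromatic ring. At this position, then, going from (4-fluorobenzyl)amino to (2,4,6-trimethylphenyl)amino, and so from a one-carbon link to an aromatic ring carried directly on the nitrogen, leaves the read-out within the scatter, and compound 1 at 970 nM, which differs from compound 3 in more than one place, cannot be read as a guide to this change alone. No measurement at hand accounts for this result.

From the compounds shown here alone, whether an unsubstituted phenyl or a cyclohexyl on this nitrogen, or a longer chain such as 2-phenylethyl, would read differently from the two groups seen so far remains open. Also open is which of the other places where compound 1 and compound 3 differ goes with the value of compound 1, as no single-place step in the compounds shown isolates any of them.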